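This account rests on a few compounds, and the source may have more. Where it says the series, first, only, none or still open, it means among the compounds named here.

The measured compounds, with their results in a functional assay on K562 cells (Homo sapiens), read by MTT assay, with a stated time of 72 h; on this read-out lower numbers stand for stronger inhibition and higher numbers for weaker inhibition:

Compound 1, `C#Cc1cn([C@@H]2O[C@H](CO)[C@@H](O)[C@H]2O)c2ncnc(C)c12`, gives 6920 nM.
Compound 2, `Cc1ncnc2c1c(-c1cc3ccccc3o1)cn2[C@@H]1O[C@H](CO)[C@@H](O)[C@H]1O`, gives 19500 nM.
Compound 3, `Cc1ncnc2c1c(-c1ccoc1)cn2[C@@H]1O[C@H](CO)[C@@H](O)[C@H]1O`, reaches only a limit of the assay, > 20000 nM.

Compound 1 has the lowest of the two numbers in this assay. The nearest number belongs to compound 2, and the step from compound 1 to compound 2 is a 2.8-fold higher number from compound 1 to compound 2 (0.45 log units; beyond the scatter). The step from compound 1 to compound 3 is an at least 2.8-fold higher number from compound 1 to compound 3 (0.46 log units; beyond the scatter), where the number for compound 3 sits at the limit of > 20000 nM in this assay, at which 1 of the 3 values shown sits.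

Compound 4, `C#Cc1cn([C@@H]2O[C@H](CO)[C@@H](O)[C@H]2O)c2ncnc(OC)c12`, differs from compound 1 in one place: methoxy in place of methyl on an aromatic carbon. Both measured steps exchange the ethynyl group for a ring, while the methyl is kept unchanged throughout, so neither step bears on the change in compound 4. For the measured compounds named here, with no comparable step to go by, the expectation rests on compound 1 alone, and no step beyond the usual scatter is expected in either direction, so the step from compound 1 to compound 4 is estimated as a 1.0-fold higher number from compound 1 to compound 4 (0.00 log units; within the scatter). Compound 4 is therefore expected to give about 7000 nM, within a range from 2500 nM to 20000 nM.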

Compound 4, half-maximal inhibitory concentration: 300 nM
Estimate against measurement, compound 4: 23-fold (1.37 log units) above, outside the stated range (below it).
By their numbers in this assay, from the lowest: compound 4; then compound 1; then compound 2. At a limit, above all of these: compound 3.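

In this assay, the position that carries methyl in compounds 1, 2 and 3 turns out to matter a great deal: methoxy there gives a 23-fold lower number from compound 1 to compound 4 (1.36 log units; beyond the scatter). The earlier steps exchanged only the ethynyl group, and those from compound 1 to compounds 2 and 3 raised the number, so this is the first change shown that lowers it, with the ethynyl group and the rest of the molecule left as they are. Nothing measured here accounts for why methoxy does so much better than methyl.

The compounds shown leave open whether an amine, a chlorine or a longer chain such as ethoxy at this position would do as well. They also leave open whether methoxy would bring a similar drop in the number alongside furan-3-yl or 1-benzofuran-2-yl in place of ethynyl.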